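Changing the Aryl Ring of a Bromophenyl Chalcone

The source may report more compounds than this note shows. Statements on the series, on what has been measured and on what is new or still open speak of the compounds shown alone.

Measured compounds:
compound 1 `O=C(COc1ccc(C(=O)/C=C/c2cccc(Br)c2)cc1)N[C@H]1CCOC1=O`: 9800 nM
compound 2 `O=C1OCC[C@@H]1NC(=S)SCCOc1ccc(Cl)cc1`: > 64000 nM

The read-out throughout is a functional assay on DU-145 cells (Homo sapiens) for antiproliferative activity, read by MTT assay, with a stated time of 72 h; on this read-out lower numbers stand for stronger inhibition and higher numbers for weaker inhibition. Among the measured compounds shown here, compound 1 gives 9800 nM in this assay, and this is the only number reported, so there is nothing else to rank it against. Compound 2 gives > 64000 nM in this assay; that figure is a limit of the assay, not a number (the limit of > 64000 nM in this assay, at which 1 of the 2 values shown sits). For the measured compounds named here, compound 2 differs from compound 1 in more than one place, so no single step between them is counted, and their two values say only that compound 1 has a number while compound 2 does not.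

The step under consideration leads to compound 3 `O=C(COc1ccc(C(=O)/C=C/c2ccc(Cl)cc2Cl)cc1)N[C@H]1CCOC1=O`, which differs from compound 1 by 2,4-dichlorophenyl in place of 3-bromophenyl on a double-bonded chain carbon bound to a double-bonded chain carbon. Going by the values given here, with no measured step between related compounds to draw on, the expected change is modest: the halogenated aryl ring is retained, and the step from compound 1 to compound 3 is estimated at a 1.4-fold lower number from compound 1 to compound 3 (0.15 log units; within the scatter), a shift that may stay within the usual scatter or lean slightly toward stronger inhibition. Compound 3 is therefore expected to give about 7000 nM in this assay, within 2500 nM to 20000 nM.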

Compound 3, half-maximal inhibitory concentration: 8610 nM
For compound 3 the middle estimate is 1.2-fold (0.09 log units) below the measured one; the measured number falls inside the stated range.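

In this assay, among the compounds shown here, the change on the double-bonded chain carbon bound to a double-bonded chain carbon gives the first step that can be read at this position: a 1.1-fold lower number from compound 1 to compound 3 (0.06 log units; within the scatter). Compound 1 and compound 3 therefore cannot be told apart on this read-out, which shows that, in this core, 2,4-dichlorophenyl can stand in place of 3-bromophenyl, even though the halogen, the number of halogen atoms and their places on the ring all differ between the two groups. The data shown offer no measured reason for this result, and the single step speaks only for these two halogenated aryl rings.

Because both groups carry halogen, the compounds shown leave open whether this position needs a halogen at all, and what an unsubstituted phenyl ring, or a phenyl ring bearing an amine or a carboxylic acid, would give there. They also leave open what each difference contributes alone, since a single chlorine at either of the two places, or a bromine in the place of the chlorines, would be needed to separate them.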